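This account rests on a few compounds, and the source may have more. Where it says the series, first, only, none or still open, it means among the compounds named here.

Measured so far:
- compound 1, `CC(=O)N1N=C(c2ccccc2)CC1c1ccc(N(C)C)cc1`: 14600 nM
- compound 2, `COc1ccc(C2CC(c3cccc([N+](=O)[O-])c3)=NN2C(C)=O)cc1`: 8210 nM
- compound 3, `CC(=O)N1N=C(c2ccco2)CC1c1ccc([N+](=O)[O-])cc1`: 21800 nM

All three were tested in a functional assay on HEp-2 cells (Homo sapiens) for cytotoxicity, read by sulforhodamine B assay, with a stated time of 48 h; on this read-out lower numbers stand for stronger inhibition and higher numbers for weaker inhibition. Compound 3 has the highest number of the three. Its nearest neighbour is compound 1, whose number is lower by an amount that stays within the usual scatter, so the two cannot be told apart. Compound 2 has a number lower than compound 3 by an amount that goes beyond the scatter.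

Compound 4, `COc1ccc(C2CC(c3ccco3)=NN2C(C)=O)cc1`, has not yet been tested in this assay. It differs from compound 3 in one place: methoxy in place of nitro on an aromatic carbon. For the measured compounds named here, no pair of measured compounds shares exactly this change, so its effect cannot be read off directly. Compound 2, which carries a methoxy at the same place on its own core, gives 8210 nM in this assay, and that is the only hint available. On that basis a modest move toward a lower number is expected, of a size a 1.6-fold lower number from compound 3 to compound 4 (0.19 log units; within the scatter) that may not clear the scatter. Compound 4 is expected to give 14000 nM, within the range 5000 nM to 40000 nM.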

Compound 4, half-maximal inhibitory concentration: 15600 nM
For compound 4 the middle estimate is 1.1-fold (0.05 log units) below the measured one; measured number inside the range.
By their numbers in this assay, from the lowest: compounds 2, 1, 4 and 3 (each within the scatter of the next, the first and the last beyond it).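

In this assay, methoxy in place of nitro on an aromatic carbon, para to a large group, gives a 1.4-fold lower number from compound 3 to compound 4 (0.15 log units; within the scatter) and so leaves the number inside the usual scatter. For the compounds shown here, this is the first comparison here that changes only this one place on an otherwise shared core, and it shows that these two quite different groups cannot be told apart at this position in this cell test. Nothing given here explains this result, so no cause can be assigned to it.

As far as these compounds go, whether the same swap would also leave the number unchanged on the core of compound 2 remains open. From the compounds shown here alone, it is also open whether a group of another kind at this position, such as a carboxylic acid, a primary amine or a longer alkoxy chain, would shift the number beyond the scatter.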